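The compounds below may be only part of what the source reports. "The series", "measured", "known", "first", "only" and "open" are said of these compounds alone.

Series notes. Compound 1 `COC(=O)C1=C(C)NC(C)=C(C(=O)OCCCl)C1c1cccc([N+](=O)[O-])c1` gives in a functional assay on HEK293 cells for antagonist activity at Voltage-dependent L-type calcium channel subunit alpha-1C (Oryctolagus cuniculus), read by FLIPR (a higher number here means a weaker inhibitor, a lower number a stronger inhibitor), a half-maximal inhibitory concentration of 26 nM. Compound 2 `CCCCCOC(=O)C1=C(C)NC(C)=C(C(=O)OCC)C1c1cccc([N+](=O)[O-])c1` gives in this assay 49 nM. Compound 1 holds the lower of the two numbers, but its gap to compound 2 lies within the scatter of repeated measurements, so the pair reads as equivalent. Compound 3 `COC(=O)C1=C(C)NC(C)=C(C(=O)OCc2ccc(OC)cc2)C1c1cccc([N+](=O)[O-])c1` carries the change (4-methoxyphenyl in place of chloromethyl on a saturated chain carbon bound to an oxygen next to a carbonyl group); cut one bond further out it reads 2-chloroethyl to 4-methoxybenzyl. For the measured compounds named here, no measured pair isolates this position. The step of a 1.3-fold lower number from compound 1 to compound 3 (0.11 log units; within the scatter) is expected to be small, if anything toward a lower number, largely inside the scatter. Compound 3 is estimated at 20 nM, range 6 nM to 70 nM.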

Compound 3, half-maximal inhibitory concentration: 51 nM
Compound 3: middle estimate off by 2.6-fold (0.41 log units), on the low side; the range from low to high includes it.
By their numbers in this assay, from the lowest: compounds 1, 2 and 3 (each within the scatter of the next).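

At this position, a 2.0-fold higher number from compound 1 to compound 3 (0.29 log units; within the scatter) in this assay accompanies the exchange of 2-chloroethyl for 4-methoxybenzyl. The position therefore takes a six-membered aromatic ring of carbon only, plus a hydrogen-bond acceptor, with no step beyond the scatter. Nothing on hand explains this step. On these data alone, whether an amine or a carboxylic acid at this position would stay within the scatter of compound 1 remains open. Also open, as far as these compounds go, is what the methoxy group contributes, as an unsubstituted benzyl group would be needed to separate it from the ring.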